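Swapping chloro for bromo on a shared oxime core

A few compounds are considered here, and "the series" means these few. Any claim that something is new, unique, unknown or untested is made for them only; others in the source may bear on it.

Measured compounds:
- compound 1, `O/N=C(\C=C\c1ccc(Cl)cc1)c1ccc(Cl)cc1`: 14100 nM
- compound 2, `O/N=C(\C=C\c1ccc(Cl)cc1)c1ccc(Br)cc1`: 24700 nM
- compound 3, `Cc1ccc(C(/C=C/c2ccc(Cl)cc2)=N/O)cc1`: 21300 nM

These three compounds were tested in an ADME assay on cells (Mus musculus, strain Balb/c) for cytotoxicity, read by MTT assay, with a stated time of 48 h (a higher number here means that more compound is tolerated, a lower number that less compound is tolerated), and all three numbers lie close together. The step from compound 1 to compound 2 is a 1.8-fold higher number from compound 1 to compound 2 (0.24 log units; within the scatter), and the underlying change is bromo in place of chloro on an aromatic carbon. Compound 3 differs from compound 1 by methyl in place of chloro on an aromatic carbon, giving a step of a 1.5-fold higher number from compound 1 to compound 3 (0.18 log units; within the scatter). Between compound 2 and compound 3 the step is a 1.2-fold lower number from compound 2 to compound 3 (0.06 log units; within the scatter).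

Compound 4, `Cc1ccc(C(/C=C/c2ccc(Br)cc2)=N/O)cc1`, has not yet been tested in this assay. It stands to compound 3 as compound 2 stands to compound 1: the change is bromo in place of chloro on an aromatic carbon, and the place line is the same word for word as for the change from compound 1 to compound 2, so this is the same change on a different core. The cores of compound 1 and compound 3 differ by methyl in place of chloro on an aromatic carbon.

Within the data shown here, the only guide is the earlier step, a 1.8-fold higher number from compound 1 to compound 2 (0.24 log units; within the scatter), which stayed within the scatter, so the expected step from compound 3 to compound 4 is a 1.4-fold higher number from compound 3 to compound 4 (0.15 log units; within the scatter), a small rise resting on that single pair. For compound 4 the expected value in this assay is 30000 nM, with a likely range from 15000 nM to 60000 nM, because compound 3 gives 21300 nM and the same change moved compound 1 to compound 2 by a 1.8-fold higher number from compound 1 to compound 2 (0.24 log units; within the scatter).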

Compound 4, half-maximal cytotoxic concentration: 34200 nM
The estimate for compound 4 lay 1.1-fold (0.06 log units) below the measured number; low and high end bracket the measured number.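

In this assay, the new case of bromo in place of chloro on an aromatic carbon gives a 1.6-fold higher number from compound 3 to compound 4 (0.21 log units; within the scatter), and this step can now be set beside the earlier one on a different core: the same change on two cores in this assay, a 1.8-fold higher number (0.24 log units; within the scatter) from compound 1 to compound 2 and a 1.6-fold higher number (0.21 log units; within the scatter) from compound 3 to compound 4, 1.1-fold (0.04 log units) apart, within the scatter of two such steps. This shows that the change carried over from the core of compound 1 to the core of compound 3 without any difference that can be told apart from ordinary repeat-to-repeat variation. It does not show that the swap itself has a real effect: each step taken alone stays within the scatter. Two cores are too few to speak for the whole series.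

The compounds shown carry only chloro, bromo or methyl on these aromatic carbons, so it remains open whether the same agreement between cores would hold for a very different group, such as an amine, a carboxylic acid or a longer chain. Going by these compounds, it is also open whether a change of that kind would give a step large enough to stand clear of the scatter, and whether such a step would then carry from one core to the other.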